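Methyl in Place of Hydrogen: Compound 4 Before Measurement

The compounds below may be only part of what the source reports. "The series", "measured", "known", "first", "only" and "open" are said of these compounds alone.

Compound 1 `O=C1/C(=C/c2ccccc2)CCc2ccccc21` is the unsubstituted member of this small set. Within the data shown here, in a functional assay on P388 cells (Mus musculus) for inhibition (a higher number here means a weaker inhibitor, a lower number a stronger inhibitor), compound 1 gives 30200 nM, the second highest of the three numbers known, and both other compounds sit within the scatter of it: compound 2 `O=C1/C(=C/c2cccc(F)c2)CCc2ccccc21` gives 31100 nM, and compound 3 `Cc1cccc(/C=C2\CCc3ccccc3C2=O)c1` gives 16300 nM. The measured steps are all small, a 1.0-fold higher number from compound 1 to compound 2 (0.01 log units; within the scatter), a 1.9-fold lower number from compound 1 to compound 3 (0.27 log units; within the scatter) and a 1.9-fold lower number from compound 2 to compound 3 (0.28 log units; within the scatter), none of them beyond the scatter.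

Compound 4 `Cc1ccc(/C=C2\CCc3ccccc3C2=O)cc1` differs from compound 1 by methyl in place of hydrogen on an aromatic carbon. Among the measured compounds shown here, the one measured step with the same kind of change, a 1.9-fold lower number from compound 1 to compound 3 (0.27 log units; within the scatter), stayed within the scatter, and the change from hydrogen to fluoro, a 1.0-fold higher number from compound 1 to compound 2 (0.01 log units; within the scatter), moved nothing either. On this basis no step beyond the scatter is expected in this assay, with a slightly lower number being the most that the data hint at. Compound 4 is therefore expected to give 20000 nM, within a range from 8000 nM to 50000 nM. The step this estimate means, a 1.5-fold lower number from compound 1 to compound 4 (0.18 log units; within the scatter), is expected to lie within the scatter.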

Compound 4, half-maximal inhibitory concentration: 17700 nM
For compound 4 the middle estimate is 1.1-fold (0.05 log units) above the measured one, and the stated range covers the measured number.
By their numbers in this assay, from the lowest: compounds 3, 4, 1 and 2 (each within the scatter of the next).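

In this assay, methyl in place of hydrogen on an aromatic carbon, para to a large group, gives a 1.7-fold lower number from compound 1 to compound 4 (0.23 log units; within the scatter), so this position joins the other place on the ring in showing no step beyond the scatter for this change. Compound 3, with its methyl on another carbon of the same ring, gives 16300 nM and compound 4 gives 17700 nM, two values within the scatter of each other, so the place of the methyl on this ring does not separate the two compounds in this assay. Nothing available here bears on why these numbers lie so close together.

The compounds shown leave open whether an amine, a carboxylic acid or a longer chain on this same carbon would produce a step beyond the scatter. They also leave open whether any change on this ring can move the number that far.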